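The compounds below may be only part of what the source reports. "The series", "measured", "known", "first", "only" and "open" are said of these compounds alone.

Compound 1 `Cc1csc(CN[C@@H]2C[C@H]3C[C@@H]([C@H]2C)C3(C)C)c1`: 12500 nM
Compound 2 `C[C@H]1[C@H](NCc2cc(C3CCCCC3)cs2)C[C@H]2C[C@@H]1C2(C)C`: 780 nM

In an ADME assay on MDCK cells (Canis lupus familiaris) for cytotoxicity, read by microscopy, with a stated time of 48 h (on this read-out lower numbers stand for higher toxicity in this test and higher numbers for lower toxicity in this test), compound 2 holds the lowest of the two numbers, with compound 1 as its nearest neighbour. Compound 3 `CCCCc1csc(CN[C@@H]2C[C@H]3C[C@@H]([C@H]2C)C3(C)C)c1` differs from compound 2 in one place: butyl in place of cyclohexyl on an aromatic carbon. Within the data shown here, the single measured step that bears on this change is a 16-fold lower number from compound 1 to compound 2 (1.20 log units; beyond the scatter), a large move from methyl to cyclohexyl. Replacing cyclohexyl with butyl undoes part of that change, so a step back toward compound 1 is expected, though not all the way. The estimate for compound 3 is 2500 nM, range 800 nM to 8000 nM, an expected step of a 3.2-fold higher number from compound 2 to compound 3 (0.51 log units; beyond the scatter).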

Compound 3, minimum cytotoxic concentration: 12500 nM
The estimate for compound 3 lay 5.0-fold (0.70 log units) below the measured number; measured number outside the range, above it.
By their numbers in this assay, from the lowest: compound 2; then compounds 1 and 3 (each within the scatter of the next).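

In this assay the low number at this position goes with the cyclohexyl group, not with just any larger carbon group: butyl in place of cyclohexyl gives a 16-fold higher number from compound 2 to compound 3 (1.20 log units; beyond the scatter) and takes back the whole drop. Butyl and methyl at this position cannot be told apart, with no change at the digits printed from compound 1 to compound 3 (within the scatter) on the same core. Nothing measured here accounts for the difference between cyclohexyl and butyl. As far as these compounds go, what remains open is whether the ring or the carbon count matters more, which hexyl, cyclopentyl or phenyl at this position could help to separate.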